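Demethylation of an Inactive Urea: Little Change Expected

The source may hold more compounds than are shown below. What is called first, only, known or untested is meant among the compounds shown, and "the series" means these compounds.

Compound 2 `COc1cc(-c2nn(-c3cccc(NC(=O)Nc4ccc(Cl)c(Cl)c4)c3)cc2-c2ccncc2)ccc1Cl` was tested in a functional assay on NCI-H522 cells (Homo sapiens) for inhibition, read by sulforhodamine B assay, with a stated time of 48 h; on this read-out lower numbers stand for higher toxicity in this test and higher numbers for lower toxicity in this test. Compound 2 reaches only a limit there, > 50000 nM, and gives no number. Compound 1 `O=C(Nc1cccc(-n2cc(-c3ccncc3)c(-c3ccc(Cl)c(O)c3)n2)c1)Nc1cccc(C(F)(F)F)c1` likewise stops at a limit in this assay, > 32500 nM. Compound 3 `O=C(Nc1cccc(-n2cc(-c3ccncc3)c(-c3ccc(Cl)c(O)c3)n2)c1)Nc1ccc(Cl)c(Cl)c1` has not yet been measured. It differs from compound 2 by hydrogen in place of methyl on an oxygen on an aromatic ring, so methoxy becomes hydroxy. Within the data shown here, no step between measured compounds is available, so no direction can be read off, and compound 1, which also carries the hydroxy group, sits at a limit too. In this assay compound 3 is expected to give 60000 nM, with a range from 20000 nM to 200000 nM. The expected step that the limit leaves unreadable from compound 2 to compound 3 is none beyond the scatter.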

Compound 3, concentration lethal to 50% of the cells: > 32500 nM
Compound 3: no number, only a limit; the forecaster's own chance of this, stated with the estimate: 85%; the middle value is on the limit's open side.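

Among these compounds, compound 1, compound 2 and compound 3 all stop at limits rather than numbers, so no step between them can be read. Going by these compounds, whether methoxy to hydroxy, or 3,4-dichlorophenyl in place of 3-(trifluoromethyl)phenyl, changes the toxicity stays open.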